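Cytotoxicity series: dithiocarbamate core, anilino to cyclohexylamino

A few compounds are considered here, and "the series" means these few. Any claim that something is new, unique, unknown or untested is made for them only; others in the source may bear on it.

Measured so far in an ADME assay on HeLa cells (Homo sapiens) for cytotoxicity, read by MTT assay, with a stated time of 24 h; a higher number here means a weaker inhibitor, a lower number a stronger inhibitor:
compound 1 `CN(C)C(=S)SC(=S)N1CCN(C(=S)SCc2ccccc2)CC1` — > 5000000 nM
compound 2 `CN(C)C(=S)SC(=S)N1CCN(C(=S)Nc2ccccc2)CC1` — > 5000000 nM

Compound 1 `CN(C)C(=S)SC(=S)N1CCN(C(=S)SCc2ccccc2)CC1` carries a benzylsulfanyl group on the thiocarbonyl carbon; in this assay compound 1 returns only a limit, > 5000000 nM. Compound 2 `CN(C)C(=S)SC(=S)N1CCN(C(=S)Nc2ccccc2)CC1` carries an anilino group in its place; in this assay compound 2 likewise returns only a limit, > 5000000 nM. The step that the two limits leave unreadable from compound 1 to compound 2 cannot be read, since both ends sit on the same limit, as the limit of > 5000000 nM in this assay, at which 2 of the 2 values shown sit, records. So compound 2 stands at the top of the range the assay reports, with no number of its own.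

Compound 3 `CN(C)C(=S)SC(=S)N1CCN(C(=S)NC2CCCCC2)CC1` is the next member. It differs from compound 2 in one place: cyclohexyl in place of phenyl on an amide-type nitrogen. Going by the values given here, no measured step bears on this change; the only step known, from benzylsulfanyl to anilino, is itself unreadable. Nothing in the data therefore points toward a readable shift in this assay, and a limit is the likeliest outcome again.

For compound 3 the estimate in this assay is 5000000 nM, with a range from 2000000 nM to 20000000 nM. The implied step a number no higher from compound 2 to compound 3 (the limit leaves the size open) is expected to be none beyond the scatter.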

Compound 3, half-maximal inhibitory concentration: > 5000000 nM
Compound 3 ended at the assay's limit; the forecaster's own chance of this, stated with the estimate: 85%; the middle value lies on the limit itself.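

No step among compound 1, compound 2 and compound 3 can be read in this assay, since all three return only a limit: the limit of > 5000000 nM in this assay, at which 3 of the 3 values shown sit.

The compounds shown leave open whether any group on the thiocarbonyl carbon of the shared core would give a compound a number of its own in this assay.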